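Expecting the Value of Compound 4

The compounds below may be only part of what the source reports. "The series", "measured", "known", "first", "only" and "open" are said of these compounds alone.

Measured in an ADME assay on Vero cells (Chlorocebus sabaeus) for cytotoxicity, read by MTT assay, with a stated time of 72 h; on this read-out lower numbers stand for stronger inhibition and higher numbers for weaker inhibition:
- Compound 1 `O=C(O)c1cn(C2CC2)c2nc(N3CCC(n4c(=O)[nH]c5cc(Cl)ccc54)CC3)c([N+](=O)[O-])cc2c1=O`: 55500 nM
- Compound 2 `CC1CN(c2nc3c(cc2[N+](=O)[O-])c(=O)c(C(=O)O)cn3-c2ccc(F)cc2)CC(C)O1`: 141000 nM
- Compound 3 `O=C(O)c1cn(-c2ccc(F)cc2)c2nc(N3CCC(N4CCCCC4)CC3)c([N+](=O)[O-])cc2c1=O`: > 126000 nM (a limit)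

Compound 3 stands at > 126000 nM, which is a limit of this assay and not a number. Compound 4 `O=C(O)c1cn(-c2ccc(F)cc2)c2nc(N3CCC(n4c(=O)[nH]c5cc(Cl)ccc54)CC3)c([N+](=O)[O-])cc2c1=O` differs from compound 3 as follows: a group of 11 heavy atoms (7 carbon, 2 nitrogen, 1 oxygen, 1 chlorine; one five-membered aromatic ring with 2 hetero atoms, one six-membered aromatic ring of carbon only) in place of a group of 6 heavy atoms (5 carbon, 1 nitrogen; one six-membered non-aromatic ring with 1 hetero atom), on a saturated ring carbon.

The one measured step among these compounds is a step that the limit leaves unreadable from compound 2 to compound 3, so no measured size carries over to this change. The nearest guide is compound 1, which carries the same entering group on a related core and gives 55500 nM in this assay. On the strength of that value, a move towards stronger inhibition is expected, with a size that remains uncertain. The estimate means an at least 2.1-fold lower number from compound 3 to compound 4 (0.32 log units; beyond the scatter), an expected step whose starting point is only a limit. Compound 4 is expected at 60000 nM. The estimated range for compound 4 runs from 25000 nM to 130000 nM.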

Compound 4, half-maximal inhibitory concentration: 53900 nM
Compound 4: the middle estimate sits 1.1-fold (0.05 log units) above what was measured, and the stated range covers the measured number.
By their numbers in this assay, from the lowest: compounds 4 and 1 (each within the scatter of the next); then compound 2.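

With the group of 11 heavy atoms in place of piperidin-1-yl on the saturated ring carbon, this assay shows an at least 2.3-fold lower number from compound 3 to compound 4 (0.36 log units; beyond the scatter). That step starts from compound 3, whose entry is a limit of the assay and not a number: the limit of > 126000 nM in this assay, at which 1 of the 4 values shown sits. With this entering group held fixed, 4-fluorophenyl in place of cyclopropyl on the aromatic nitrogen gives a 1.0-fold lower number from compound 1 to compound 4 (0.01 log units; within the scatter), so the two groups on that nitrogen are not told apart in this assay.

Going by these compounds, it remains open how far the number would move with fluorine in place of the chlorine of the entering group, or with a small amine such as dimethylamino on the same ring carbon. On these data alone, the full size of the step from compound 3 also stays open, as does whether cyclopropyl and 4-fluorophenyl would stay within the scatter of each other alongside piperidin-1-yl.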